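The source may report more compounds than this note shows. Statements on the series, on what has been measured and on what is new or still open speak of the compounds shown alone.

Measured so far in an in vitro functional assay on HEK293-A cells for antagonist activity at metabotropic glutamate receptor 5 (Rattus norvegicus), read by calcium flux; on this read-out higher numbers stand for weaker inhibition and lower numbers for stronger inhibition: compound 1 `N#Cc1cc(F)cc(C(=O)Nc2ccccn2)c1` gives 3010 nM, compound 2 `N#Cc1cc(F)cc(C(=O)Nc2cccc(Cl)c2)c1` gives 45 nM, and compound 3 `Cc1cccc(NC(=O)c2cc(F)cc(C#N)c2)c1` gives 122 nM.

Compound 3 stands second highest of the three numbers, nearest to compound 2 and far from compound 1. Among the compounds with values here, the only single-point step among them is a 2.7-fold higher number from compound 2 to compound 3 (0.43 log units; beyond the scatter). Compound 4 `N#Cc1cccc(NC(=O)c2cc(F)cc(C#N)c2)c1` differs from compound 3 by cyano in place of methyl on an aromatic carbon. Within the data shown here, no measured pair shows methyl giving way to cyano, so the sole guide is that exchanging one group for another on that aromatic carbon moved the number modestly, as seen in a 2.7-fold higher number from compound 2 to compound 3 (0.43 log units; beyond the scatter). A step of similar or smaller size is expected, in either direction. For compound 4 the number is therefore estimated at 100 nM, ranging from 30 nM to 400 nM, which means a 1.2-fold lower number from compound 3 to compound 4 (0.09 log units; within the scatter).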

Compound 4, half-maximal inhibitory concentration: 489 nM
Estimate against measurement, compound 4: 4.9-fold (0.69 log units) below, and the stated range ends below it.
By their numbers in this assay, from the lowest: compound 2; then compound 3; then compound 4; then compound 1.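

With a 4.0-fold higher number from compound 3 to compound 4 (0.60 log units; beyond the scatter) and an 11-fold higher number from compound 2 to compound 4 (1.04 log units; beyond the scatter) as the steps, cyano on this aromatic carbon gives weaker inhibition than either methyl or chloro. The position therefore responds more strongly to its group than the chloro-to-methyl exchange alone showed, with inhibition weakening from chloro to methyl to cyano. Nothing available here explains this order. From the compounds shown here alone, whether an amine, a methoxy group or a longer chain on this carbon would match chloro remains open. So does whether this order would hold with the group elsewhere on the ring.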